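Benzylsulfanyl for benzylamino on a deoxyribosyl purine-like scaffold

The compounds below may be only part of what the source reports. "The series", "measured", "known", "first", "only" and "open" are said of these compounds alone.

The set comprises compound 1 `[O-][n+]1ccc2[nH]cnc2c1`, compound 2 `OC[C@H]1O[C@@H](n2cnc3c(NCc4ccccc4)nccc32)C[C@@H]1O`, compound 3 `[N-]=[N+]=Nc1nccc2c1ncn2C1O[C@H](CO)[C@@H](O)[C@H]1O` and the not yet measured compound 4 `OC[C@H]1O[C@@H](n2cnc3c(SCc4ccccc4)nccc32)C[C@@H]1O`. All were, or are to be, tested in a functional assay on EL4 cells (Mus musculus) for inhibition, tested at 100 uM; on this read-out lower numbers stand for less inhibition and higher numbers for more inhibition at the one concentration tested (going by the name of the read-out). In this assay compound 2 gives 8%, and compound 1 gives 5%, a value that lies within the usual scatter of that of compound 2. For compound 3 the assay reports only a limit, < 5%. Among the numbers shown, compound 2 stands at the higher end, but its distance to compound 1 does not exceed the scatter, so no order between the two can be claimed.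

Compound 4 differs from compound 2 in one place: benzylsulfanyl in place of benzylamino on an aromatic carbon. Within the data shown here, no comparable step between two measured compounds is available. With every measured value low, the step from compound 2 to compound 4 is expected to be a number 1 percentage points lower from compound 2 to compound 4 (within the scatter), that is, none beyond the scatter. Compound 4 is therefore estimated to give 7%, between 0% and 20%.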

Compound 4, a percentage reported as inhibition, at one concentration (the size of the read-out at that concentration, not a potency): 11%
Compound 4: the middle estimate sits 4 percentage points below what was measured; the range from low to high includes it.
By their numbers in this assay, from the lowest: compounds 1, 2 and 4 (each within the scatter of the next).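

In this assay, among these compounds, benzylsulfanyl in place of benzylamino on an aromatic carbon next to the ring nitrogen gives the first readable step at this position, a number 3 percentage points higher from compound 2 to compound 4 (within the scatter). Benzylsulfanyl has no hydrogen-bond donor where benzylamino has one, yet at this single concentration the read-out does not separate the two groups. Compound 3 is reported only as a limit of the assay: the limit of < 5% in this assay, at which 1 of the 4 values shown sits.

The compounds shown leave open whether any group at this position can lift inhibition beyond the scatter, as a primary amine, a carboxylic acid or a longer alkyl chain in place of the benzyl groups might or might not. Among the compounds shown here, with only this one step, they also leave open whether the same exchange would behave alike on a different sugar or with a substituted benzyl ring.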